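A few compounds are considered here, and "the series" means these few. Any claim that something is new, unique, unknown or untested is made for them only; others in the source may bear on it.

Measured so far:
compound 1, `Nc1nc(O)c2c(n1)n(C1OC(CO)[C@@H](O)[C@H]1O)c(=O)n2CC(O)CSc1ccccc1` — 12%
compound 2, `C=CCn1c(=O)n(C2OC(CO[Si](C)(C)C(C)(C)C)[C@@H](O)[C@H]2O)c2nc(N)nc(O)c21` — 5%

In a functional assay on the whole organism (B cells) with Mus musculus as the target (on this read-out higher numbers stand for larger maximal responses and lower numbers for smaller maximal responses), compound 1 gives 12%. Compound 2 gives 5%, a number separated from that of compound 1 by a gap inside the usual scatter, so the two cannot be ranked against each other; both show small maximal responses.

Compound 3, `CCCCn1c(=O)n(C2OC(CO)[C@@H](O)[C@H]2O)c2nc(N)nc(O)c21`, is not yet measured in this assay. It differs from compound 1 in one place: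

propyl in place of 1-hydroxy-2-(phenylsulfanyl)ethyl on a saturated chain carbon bound to an aromatic nitrogen

Within the data shown here, no step between two measured compounds is known, so nothing shows how a change at this position moves the read-out. With both measured numbers lying low, the step of a number 2 percentage points lower from compound 1 to compound 3 (within the scatter) is expected to stay within the scatter rather than move clearly in either direction. Compound 3 is accordingly estimated at 10%, with a range from 3% to 22%.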

Compound 3, largest response reached (reported as maximal response), in percent of the reference or control that the assay uses: 86%
Compound 3: the middle estimate sits 76 percentage points below what was measured, and the stated range ends below it.
By their numbers in this assay, from the lowest: compounds 2 and 1 (each within the scatter of the next); then compound 3.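

In this assay, the position on a saturated chain carbon bound to an aromatic nitrogen proves highly sensitive: propyl in place of 1-hydroxy-2-(phenylsulfanyl)ethyl gives a number 74 percentage points higher from compound 1 to compound 3 (beyond the scatter) on an otherwise unchanged core. The low numbers seen so far therefore do not set a ceiling for this core. No measurement shown explains the step. The compounds shown leave open which part of the departing group matters, and whether a 2-hydroxypropyl group or a 3-(phenylsulfanyl)propyl group would keep the large response, or a longer chain such as hexyl.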